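The compounds below may be only part of what the source reports. "The series", "measured", "known", "first", "only" and "open" are said of these compounds alone.

The measured compounds:

Compound 1 `Cc1ccc2cc(CN(Cc3ccc(C(C)C)cc3)Cc3ccccc3F)c(=O)[nH]c2c1` — in a toxicity assay on MDCK cells (Canis lupus familiaris) for cytotoxicity, read by crystal violet staining, with a stated time of 48 h (on this read-out higher numbers stand for lower toxicity in this test and lower numbers for higher toxicity in this test), compound 1 gives > 33000 nM, which is a limit of the assay rather than a number.
Compound 2 `CCc1ccc2[nH]c(=O)c(CN(Cc3ccc(O)cc3)Cc3ccc(C(C)(C)C)cc3)cc2c1` — in this assay compound 2 gives > 10000 nM, again only a limit.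
Compound 3 `CCOc1ccc(CN(Cc2ccc(C(C)(C)C)cc2)Cc2cc3cc(C)ccc3[nH]c2=O)cc1` — in this assay compound 3 gives > 10000 nM, also a limit.

Compound 3 therefore stands at the limit of > 10000 nM in this assay, at which 2 of the 3 values shown sit. Compound 1 sits at the limit of > 33000 nM in this assay, at which 1 of the 3 values shown sits. None of the three values is a number. Compound 4 `Cc1ccc2[nH]c(=O)c(CN(Cc3ccc(C(C)(C)C)cc3)C(C)c3ccc(N(C)C)c(Cl)c3)cc2c1` differs from compound 3 in one place: 1-(3-chloro-4-(dimethylamino)phenyl)ethyl in place of 4-ethoxybenzyl on an amine nitrogen. Within the data shown here, no step between measured compounds is available, so the size of this change cannot be inferred from the data. Compound 4 is expected to remain near the same limit, with the step that the limit leaves unreadable from compound 3 to compound 4 expected to be no larger than the scatter. The estimate for compound 4 in this assay is 15000 nM, ranging from 4000 nM to 50000 nM.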

Compound 4, half-maximal cytotoxic concentration: 9800 nM
For compound 4 the middle estimate is 1.5-fold (0.18 log units) above the measured one; measured number inside the range.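

In this assay, among these compounds, compound 4 gives 9800 nM as the only value here that is a number and not a limit. Placing 1-(3-chloro-4-(dimethylamino)phenyl)ethyl on the amine nitrogen gives an at least 1.0-fold lower number from compound 3 to compound 4 (0.00 log units; that floor lies within the scatter) and so shows no change beyond the scatter. The true size of the step cannot be read, because compound 3 stands at a limit: the limit of > 10000 nM in this assay, at which 2 of the 4 values shown sit.

As far as these compounds go, it remains open which part of the new group counts. A 4-(dimethylamino)benzyl group, lacking both the chlorine and the extra methyl of the ethyl link, would begin to separate them.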